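Ester in place of amide on a folate-type side chain

This account rests on a few compounds, and the source may have more. Where it says the series, first, only, none or still open, it means among the compounds named here.

Measured so far:
compound 1 `CN(Cc1cnc2nc(N)nc(N)c2n1)c1ccc(C(=O)NC(CCC(=O)NN)C(=O)O)cc1` gives 0.012 uM
compound 2 `CCCCNC(=O)CCC(NC(=O)c1ccc(N(C)Cc2cnc3nc(N)nc(N)c3n2)cc1)C(=O)O` gives 0.0033 uM

Going by the values given here, in an assay on L1210 cells for inhibition of Dihydrofolate reductase (Mus musculus) (on this read-out higher numbers stand for weaker inhibition and lower numbers for stronger inhibition), compound 2 holds the lower of the two numbers; the only other compound, compound 1, lies higher by a 3.6-fold lower number from compound 1 to compound 2 (0.56 log units; beyond the scatter). Compound 3 `CN(Cc1cnc2nc(N)nc(N)c2n1)c1ccc(C(=O)NC(CCC(=O)OC(C)(C)C)C(=O)O)cc1` differs from compound 2 by tert-butoxy in place of butylamino on a carbonyl carbon. Among the compounds with values here, the single measured step changed the same distal amide and was modest in size, so the shift to an ester here is expected to stay close to compound 2, within a 1.2-fold higher number from compound 2 to compound 3 (0.08 log units; within the scatter). Compound 3 is therefore estimated at 0.004 uM, expected between 0.0015 uM and 0.012 uM.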

Compound 3, concentration for 50% inhibition: 0.0029 uM
Estimate against measurement, compound 3: 1.4-fold (0.14 log units) above; the range from low to high includes it.
By their numbers in this assay, from the lowest: compounds 3 and 2 (each within the scatter of the next); then compound 1.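

In this assay, tert-butoxy in place of butylamino on this carbonyl carbon gives a 1.1-fold lower number from compound 2 to compound 3 (0.06 log units; within the scatter), so losing the amide hydrogen and its nitrogen link leaves the read-out within the scatter for this pair. Set against aminoamino, tert-butoxy gives a 4.1-fold lower number from compound 1 to compound 3 (0.62 log units; beyond the scatter), so both butylamino and tert-butoxy now stand beyond the scatter from aminoamino. No measured property here bears on why these two groups read alike. Compound 3 differs from compound 2 in both the linking atom and the branching of the chain, and unbranched butoxy or tert-butylamino would be needed to tell these apart. As far as these compounds go, how a free carboxylic acid on this carbonyl carbon would read remains open.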